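Taking the Methoxy off the Ring of Compound 1

This account rests on a few compounds, and the source may have more. Where it says the series, first, only, none or still open, it means among the compounds named here.

Compound 1 `CCCOCNc1n[n+]([O-])c2cc(OC)ccc2[n+]1[O-]`: 6570 nM
Compound 2 `COc1ccc(COCNc2n[n+]([O-])c3ccccc3[n+]2[O-])cc1`: 14500 nM
Compound 3 `CCCCOCNc1n[n+]([O-])c2ccccc2[n+]1[O-]`: 14700 nM

In a functional assay on PC-3 cells (Homo sapiens) for cytotoxicity, read by MTT assay, with a stated time of 72 h (on this read-out lower numbers stand for stronger inhibition and higher numbers for weaker inhibition), compound 1 gives the lowest of the three numbers, and both compound 2 and compound 3 sit beyond the scatter above it. Compound 4 `CCCOCNc1n[n+]([O-])c2ccccc2[n+]1[O-]` differs from compound 1 by hydrogen in place of methoxy on an aromatic carbon. For the measured compounds named here, no measured pair isolates this change. Going by the values given here, the only measured step, a 1.0-fold higher number from compound 2 to compound 3 (0.01 log units; within the scatter), alters the chain rather than the ring and lies within the scatter, so it says little here. Compound 3 shares the bare ring of compound 4 but carries a butyl chain, and its number stands above that of compound 1. A modest rise is therefore expected: a 1.5-fold higher number from compound 1 to compound 4 (0.18 log units; within the scatter). Compound 4 is estimated at 10000 nM, with a range from 4000 nM to 25000 nM.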

Compound 4, half-maximal inhibitory concentration: 14200 nM
Estimate against measurement, compound 4: 1.4-fold (0.15 log units) below, within the range that was stated.
By their numbers in this assay, from the lowest: compound 1; then compounds 4, 2 and 3 (each within the scatter of the next).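

In this assay, hydrogen in place of methoxy on this aromatic carbon gives a 2.2-fold higher number from compound 1 to compound 4 (0.33 log units; beyond the scatter) and is the only step shown that exceeds the scatter. The chain changes on the ring without methoxy give a 1.0-fold lower number from compound 3 to compound 4 (0.02 log units; within the scatter) and a 1.0-fold lower number from compound 2 to compound 4 (0.01 log units; within the scatter) and leave the number within the scatter. Nothing measured here explains why the methoxy step is the larger one.

As far as these compounds go, whether an amine or an ethoxy group at this ring position would match methoxy remains open. So does whether the chain matters once methoxy is present, since only compound 1 carries it.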